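From tert-Butyl to Pyrrolidinylmethyl on a Fused Core

The compounds below may be only part of what the source reports. "The series", "measured", "known", "first", "only" and "open" are said of these compounds alone.

Compound 2 `CC(C)(C)c1nnc2c(C#N)c(N3CCC(c4ccccc4)CC3)ccn12` stands lowest of the two numbers in a functional assay on CHO cells for positive allosteric modulation of metabotropic glutamate receptor 2 (Homo sapiens), read by GTPgammaS binding, with a stated time of 30 min (a lower number here means a smaller maximal response, a higher number a larger maximal response), where compound 2 gives 207%. Compound 1 `N#Cc1c(N2CCC(c3ccccc3)CC2)ccn2c(CC3CC3)nnc12` gives 278% in this assay, and the step of a number 71 percentage points lower from compound 1 to compound 2 (beyond the scatter) went with tert-butyl in place of cyclopropylmethyl on an aromatic carbon. Compound 3 `N#Cc1c(N2CCC(c3ccccc3)CC2)ccn2c(CN3CCCC3)nnc12` differs from compound 2 in one place: (pyrrolidin-1-yl)methyl in place of tert-butyl on an aromatic carbon. Among the compounds with values here, only that one step bears on the change, and it was large; the direction expected here is upward, with wide uncertainty. The expected step is a number 43 percentage points higher from compound 2 to compound 3 (beyond the scatter). For compound 3 the estimate is 250%, ranging from 185% to 315%.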

Compound 3, largest response reached (Emax), in percent of the reference or control that the assay uses: 240%
The estimate for compound 3 lay 10 percentage points above the measured number, and the stated range covers the measured number.
By their numbers in this assay, from the lowest: compound 2; then compound 3; then compound 1.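

In this assay the position between two ring nitrogen atoms also accommodates a group holding a nitrogen and a five-membered non-aromatic ring, with a change of a number 33 percentage points higher from compound 2 to compound 3 (beyond the scatter) and a response that lies clear of both earlier groups. On the same saturated chain carbon, pyrrolidin-1-yl in place of cyclopropyl gives a number 38 percentage points lower from compound 1 to compound 3 (beyond the scatter) and so shows that what that carbon carries also counts. Nothing at hand explains these shifts. Going by these compounds, whether the nitrogen or the ring goes with the change stays open; an open-chain dimethylaminomethyl group or a morpholin-4-ylmethyl group would help separate the two.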